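Methyl on the aryl ring: one change across two cores

A few compounds are considered here, and "the series" means these few. Any claim that something is new, unique, unknown or untested is made for them only; others in the source may bear on it.

Measured in a functional assay on A549 cells (Homo sapiens) for antiproliferative activity, read by MTT assay, with a stated time of 24 h; a higher number here means a weaker inhibitor, a lower number a stronger inhibitor:
compound 1 `O=c1[nH]cc(S(=O)(=O)Nc2cccc(-c3cn(-c4ccccc4)nn3)c2)c(=O)[nH]1`: 12700 nM
compound 2 `Cc1ccccc1-n1cc(-c2cccc(NS(=O)(=O)c3c[nH]c(=O)[nH]c3=O)c2)nn1`: 5470 nM
compound 3 `O=c1[nH]cc(S(=O)(=O)Nc2ccc(-c3cn(-c4ccccc4)nn3)cc2)c(=O)[nH]1`: 7170 nM

Compound 1 and compound 2 differ by methyl in place of hydrogen on an aromatic carbon; the step is a 2.3-fold lower number from compound 1 to compound 2 (0.37 log units; beyond the scatter). Compound 3 holds the same atoms as compound 1 joined differently; the difference between the two cores is not broken down here. Against compound 3 stands the unmeasured compound 4 `Cc1ccccc1-n1cc(-c2ccc(NS(=O)(=O)c3c[nH]c(=O)[nH]c3=O)cc2)nn1`, which differs from compound 3 by methyl in place of hydrogen on an aromatic carbon. This is the same change as that from compound 1 to compound 2, with the same surroundings at the place. Among the compounds with values here, only one earlier step is available as a guide, so for compound 4 the expected step is a 2.2-fold lower number from compound 3 to compound 4 (0.35 log units; beyond the scatter). Within the data shown here, that expectation rests on the single measured step of a 2.3-fold lower number from compound 1 to compound 2 (0.37 log units; beyond the scatter). Compound 4 is therefore estimated at 3200 nM, within a range from 1500 nM to 7000 nM.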

Compound 4, half-maximal inhibitory concentration: 3130 nM
Estimate against measurement, compound 4: 1.0-fold (0.01 log units) above; low and high end bracket the measured number.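

In this assay, the change from phenyl to 2-methylphenyl gives a 2.3-fold lower number from compound 3 to compound 4 (0.36 log units; beyond the scatter), and this matches the step on the other core: the same change on two cores in this assay, a 2.3-fold lower number (0.37 log units; beyond the scatter) from compound 1 to compound 2 and a 2.3-fold lower number (0.36 log units; beyond the scatter) from compound 3 to compound 4, 1.0-fold (0.01 log units) apart, within the scatter of two such steps Across these two pairs, the methyl step carries from one core to the other with no difference in size. Within the data shown here, the finding rests on only two pairs, one cell line and one read-out, so it does not show why the step arises or whether it would hold on any further core.

Going by these compounds, it remains open whether a larger group, such as ethyl or methoxy, would give a similar step at this place. A carboxylic acid or an amine on the same ring is also untested by the compounds shown.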